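Side-chain exchange at the ester of a dihydropyridine-type series

A few compounds are considered here, and "the series" means these few. Any claim that something is new, unique, unknown or untested is made for them only; others in the source may bear on it.

Measured compounds, in a functional assay on thoracic aorta for inhibition of Voltage-gated L-type calcium channel (Rattus norvegicus); a lower number here means a stronger inhibitor, a higher number a weaker inhibitor:
compound 1 `CC1=NC(C)=C(C(=O)O)C(c2cccc(F)c2)/C1=C(\O)OC/C=C/c1ccccc1`: 20 nM
compound 2 `CC1=NC(C)=C(C(=O)O)C(c2cccc(Cl)c2)/C1=C(\O)OC/C=C/c1ccccc1`: 20 nM
compound 3 `CC1=NC(C)=C(C(=O)O)C(c2cccc(Cl)c2)/C1=C(\O)OC/C=C/c1ccc(C)cc1`: 6.8 nM

Compound 3 gives the lowest number of the three, and its step to each of the other two lies beyond the scatter. Going by the values given here, the two steps so far are small: no change at the digits printed from compound 1 to compound 2 (within the scatter), and a 2.9-fold lower number from compound 2 to compound 3 (0.47 log units; beyond the scatter). Among the compounds with values here, the second of these is the only step that touches the side chain on the ester oxygen, and it shows that the methyl on the aromatic ring of that chain contributes modestly.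

Compound 4 `CC1=NC(C)=C(C(=O)O)C(c2cccc(Cl)c2)/C1=C(\O)OCC(=O)Nc1ccccc1` keeps the chloro ring of compound 3 and changes only the ester side chain: phenylcarbamoyl in place of 2-(4-methylphenyl)ethenyl on a saturated chain carbon bound to an oxygen on an unsaturated carbon. Within the data shown here, no measured step bears on this exchange directly; the methyl that is lost cost, in the step from compound 2 to compound 3, a modest amount, and what the new amide contributes is uncharted in this set. The step is therefore expected to land somewhere between no change and a modest rise in number, with wide uncertainty, a 4.4-fold higher number from compound 3 to compound 4 (0.64 log units; beyond the scatter).

For compound 4 in this assay the estimate is 30 nM, within a range of 8 nM to 120 nM.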

Compound 4, half-maximal inhibitory concentration: 50 nM
The estimate for compound 4 lay 1.7-fold (0.22 log units) below the measured number; measured number inside the range.
By their numbers in this assay, from the lowest: compound 3; then compounds 1 and 2 (each within the scatter of the next); then compound 4.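

Until now only ring substituents had changed; here the ester side chain itself is exchanged, and in this assay this position responds to that exchange, with a 7.4-fold higher number from compound 3 to compound 4 (0.87 log units; beyond the scatter) against the methylated chain and a 2.5-fold higher number from compound 2 to compound 4 (0.40 log units; beyond the scatter) against the unmethylated one. The second step is the cleaner reading of the exchange, since compound 2 and compound 4 differ only in phenylcarbamoyl in place of 2-phenylethenyl, whereas the first step also gives up the methyl on the aromatic ring. The entering and leaving groups match in heavy atoms and in their single aromatic ring, so the shift goes with the change in chain composition rather than with a change in those counts, and no measurement here accounts for it.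

From the compounds shown here alone, it remains open whether the amide hydrogen or the carbonyl carries the shift, a question that a methyl on the amide nitrogen, a reversed amide or a simple ester at the end of the chain would address. Also unsettled is whether 4-methylphenyl on the carbamoyl nitrogen would repeat the gain of a 2.9-fold lower number from compound 2 to compound 3 (0.47 log units; beyond the scatter) in this new chain, or whether a longer chain or a terminal amine would behave differently.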